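The source may hold more compounds than are shown below. What is called first, only, known or untested is meant among the compounds shown, and "the series" means these compounds.

In a functional assay on L929 cells (Mus musculus) for inhibition, read by MTT assay, with a stated time of 5 days (on this read-out lower numbers stand for stronger inhibition and higher numbers for weaker inhibition), the values so far are:

- Compound 1 `COc1ccc(N(Cc2ccccc2)CC(C)C)cc1` gives 10 ug/mL
- Compound 2 `COc1ccc(N(Cc2ccc([N+](=O)[O-])cc2)CC(C)C)cc1` gives > 40 ug/mL as a limit, not a number

Compound 2 therefore has no exact position on the scale: the limit of > 40 ug/mL in this assay, at which 1 of the 2 values shown sits, is all that can be said of it.

Compound 3 `COc1ccc(N(Cc2ccccc2)Cc2ccc([N+](=O)[O-])cc2)cc1` has not yet been measured. It differs from compound 2 by phenyl in place of isopropyl on a saturated chain carbon bound to a nitrogen on an aromatic ring. Within the data shown here, no measured step makes this swap. The nearest evidence is the step of an at least 4.0-fold higher number from compound 1 to compound 2 (0.60 log units; beyond the scatter), which put nitro in place of hydrogen on an aromatic carbon and lies beyond the scatter. Compound 3 keeps that nitro group, so the higher number seen in the step of an at least 4.0-fold higher number from compound 1 to compound 2 (0.60 log units; beyond the scatter) is expected to persist in this assay, and another reading that is only a limit would be no surprise. The expected change is an at least 1.1-fold lower number from compound 2 to compound 3 (0.05 log units; that floor lies within the scatter), an estimated step within the scatter. For compound 3 the estimated value is 35 ug/mL, with an expected range of 15 ug/mL to 80 ug/mL.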

Compound 3, half-maximal inhibitory concentration: > 40 ug/mL
Compound 3 gave a limit, no number; the forecaster's own chance of this, stated with the estimate: 55%; at least 1.1-fold (0.05 log units) between middle value and limit.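

In this assay compound 3 gives > 40 ug/mL, a limit and not a number. Compound 2 also gives only a limit, so no step can be read between compound 2 and compound 3. The compounds shown leave open whether phenyl in place of isopropyl changes inhibition at all, and where either compound's true value lies.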